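The compounds below may be only part of what the source reports. "The series", "measured", "known", "first", "only" and "open" are said of these compounds alone.

Of the compounds shown here, three built on one shared core have been measured in an assay on Sf9 cells for inhibition of Leucine-rich repeat serine/threonine-protein kinase 2 (Homo sapiens), read by TR-FRET, with stated times of 30 min and 2 h; a higher number here means a weaker inhibitor, a lower number a stronger inhibitor. Compound 1 `O=C(Nc1ccnnc1)c1cc(C(F)(F)F)ccc1OCc1ccccc1` gives 15.9 nM, compound 2 `O=C(Nc1cccc(Cl)c1)c1cc(C(F)(F)F)ccc1OCc1ccc(F)cc1` gives 12.6 nM, and compound 3 `O=C(Nc1ccnnc1)c1cc(N2CCC(F)CC2)ccc1OCc1ccccc1` gives 39.8 nM. Compound 3 therefore stands highest of the three numbers, which makes it the weakest inhibitor of this small set. Going by the values given here, the only single-point comparison that reaches it is a 2.5-fold higher number from compound 1 to compound 3 (0.40 log units; beyond the scatter), which shows that exchanging trifluoromethyl for 4-fluoropiperidin-1-yl on the aromatic carbon cost a modest amount of potency. Compound 2 differs from compound 3 in more than one place, so its value can only be set beside that of compound 3 without drawing a step.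

Compound 4 `CN1CC2(C1)CN(c1ccc(OCc3ccccc3)c(C(=O)Nc3ccnnc3)c1)C2` is not yet measured. It arises from compound 3 by a group of 8 heavy atoms (6 carbon, 2 nitrogen; 2 four-membered non-aromatic rings with 1 hetero atom each) in place of a group of 7 heavy atoms (5 carbon, 1 nitrogen, 1 fluorine; one six-membered non-aromatic ring with 1 hetero atom), on an aromatic carbon, so one saturated amine ring gives way to another at the same position, meta to a (pyridazin-4-yl)carbamoyl group and para to a benzyloxy group. Among the compounds with values here, the one measured step at this position, a 2.5-fold higher number from compound 1 to compound 3 (0.40 log units; beyond the scatter), was modest and upward; no measured step compares two such rings with each other. The expectation is therefore a number near that of compound 3, with a possible further rise, giving an expected step of a 1.3-fold higher number from compound 3 to compound 4 (0.10 log units; within the scatter). Compound 4 is estimated at 50 nM in this assay, within a range from 15 nM to 160 nM.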

Compound 4, half-maximal inhibitory concentration: 25.1 nM
For compound 4 the middle estimate is 2.0-fold (0.30 log units) above the measured one, and the stated range covers the measured number.
By their numbers in this assay, from the lowest: compounds 2, 1, 4 and 3 (each within the scatter of the next, the first and the last beyond it).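

In this assay, the group with two four-membered rings cannot be told apart from 4-fluoropiperidin-1-yl at this aromatic carbon, with a 1.6-fold lower number from compound 3 to compound 4 (0.20 log units; within the scatter). It also cannot be told apart from trifluoromethyl, with a 1.6-fold higher number from compound 1 to compound 4 (0.20 log units; within the scatter), so this larger group with two ring nitrogens matches the small trifluoromethyl group here, even though the earlier exchange for 4-fluoropiperidin-1-yl gave a 2.5-fold higher number from compound 1 to compound 3 (0.40 log units; beyond the scatter). No supporting evidence is available to explain these results.

The compounds shown leave open how a morpholin-4-yl ring or an open-chain dimethylamino group would compare at this carbon, and whether the methyl group on the nitrogen of the new group matters. They also leave open whether the new group would give a similar result with the amide and ether groups of compound 2.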